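A few compounds are considered here, and "the series" means these few. Any claim that something is new, unique, unknown or untested is made for them only; others in the source may bear on it.

Measured so far in a functional assay on MDA-MB-231 cells (Homo sapiens), read by microscopy and transwell migration, with a stated time of 24 h (a higher number here means a weaker inhibitor, a lower number a stronger inhibitor), and set out by compound:

- compound 1 `COc1cc(-c2csc(NC(=O)c3ccccc3)n2)cc(OC)c1OC` gives > 50000 nM as a limit of the assay, not a number
- compound 2 `COc1cc(-c2csc(N(C)C(=O)c3ccccc3)n2)cc(OC)c1OC` gives 10000 nM as a true number

Going by the values given here, compound 2 holds the only true number so far, so it cannot yet be ranked against another number. Compound 3 `COc1ccc(C(=O)N(C)c2nc(-c3cc(OC)c(OC)c(OC)c3)cs2)cc1OC` carries 3,4-dimethoxyphenyl in place of phenyl on a carbonyl carbon and is otherwise the same as compound 2. Among the compounds with values here, the one measured step is an at least 5.0-fold lower number from compound 1 to compound 2 (0.69 log units; beyond the scatter) and sits on the amide-type nitrogen, not at this place. Within the data shown here, no step at this place has been measured. The expectation is therefore a loose one: a modest move in this assay toward a lower number. The expected change is a 3.3-fold lower number from compound 2 to compound 3 (0.52 log units; beyond the scatter) as a working estimate. For compound 3 the estimate is 3000 nM with an expected range from 300 nM to 20000 nM in this reading.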

Compound 3, half-maximal inhibitory concentration: > 25000 nM
Compound 3 ended at the assay's limit; the forecaster's own chance of this, stated with the estimate: 15%; middle value at least 8.3-fold (0.92 log units) away from the limit.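

Going by these compounds alone, the earlier compounds varied only the amide-type nitrogen, and compound 3 gives the first reading on a carbonyl carbon. In this assay, 3,4-dimethoxyphenyl in place of phenyl gives an at least 2.5-fold higher number from compound 2 to compound 3 (0.39 log units; beyond the scatter), a move opposite in direction to the one with methyl on the amide-type nitrogen, an at least 5.0-fold lower number from compound 1 to compound 2 (0.69 log units; beyond the scatter). The reading for compound 3 is a limit of the assay and not a number, and the step therefore has a lower bound only: the limit of > 25000 nM in this assay, at which 1 of the 3 values shown sits.

The compounds shown leave open whether one methoxy group alone would give the same move as the 3,4-dimethoxyphenyl group. They also leave open whether any other group on this carbonyl carbon, such as a phenyl carrying a single fluorine or an amine, would give a lower number than compound 2.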